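This account rests on a few compounds, and the source may have more. Where it says the series, first, only, none or still open, it means among the compounds named here.

Measured compounds:
Compound 1, `Nc1scc(CN2CCN(c3ccc(OC(F)(F)F)cc3)CC2)c1C(=O)c1ccc(Cl)cc1`: 1%
Compound 2, `Nc1scc(CN2CCN(c3cc(F)cc(F)c3)CC2)c1C(=O)c1ccc(Cl)cc1`: 2%

In an assay on CHO cells for displacement of a labelled ligand from adenosine receptor A3 (Homo sapiens), read by scintillation counting, with a stated time of 120 min, tested at 10 uM (on this read-out lower numbers stand for less inhibition and higher numbers for more inhibition at the one concentration tested (going by the name of the read-out)), compound 2 gives 2%, and the gap to compound 1, a number 1 percentage points higher from compound 1 to compound 2 (within the scatter), lies within the scatter, so the two numbers cannot be told apart. Compound 3, `Nc1scc(CN2CCN(c3cc(F)ccc3F)CC2)c1C(=O)c1ccc(Cl)cc1`, is not yet measured; it differs from compound 2 by 2,5-difluorophenyl in place of 3,5-difluorophenyl on an amine nitrogen in a ring. For the measured compounds named here, the only step that bears on it, a number 1 percentage points higher from compound 1 to compound 2 (within the scatter), also swapped the aryl group on that ring nitrogen and changed nothing beyond the scatter, so no change beyond the scatter is expected here either: no change at the digits printed from compound 2 to compound 3 (within the scatter). Compound 3 is therefore estimated at 2%, between 0% and 10%.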

Compound 3, a percentage reported as inhibition, at one concentration (the size of the read-out at that concentration, not a potency): 2%
For compound 3 middle estimate and measured number coincide at the digits printed; low and high end bracket the measured number.
By their numbers in this assay, from the lowest: compounds 1, 2 and 3 (each within the scatter of the next).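

In this assay, the same atoms joined differently on the phenyl ring give no change at the digits printed from compound 2 to compound 3 (within the scatter), so relocating a fluorine on this aryl group does not take the number outside the scatter. The 2,5-difluorophenyl group in place of 4-(trifluoromethoxy)phenyl gives a number 1 percentage points higher from compound 1 to compound 3 (within the scatter), so these three aryl groups on the ring nitrogen cannot be told apart here. No measurement is available to explain this result.

Still open, as far as these compounds go, is whether a different group on that nitrogen, such as a benzyl group or a phenyl ring bearing a carboxylic acid, would give a number beyond the scatter.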